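The source may hold more compounds than are shown below. What is called first, only, known or untested is meant among the compounds shown, and "the series" means these compounds.

Three compounds of this series have a measured lipophilicity. Compound 3 `CC(C)Oc1ccc(-c2nnc(-c3ccnn3C)s2)cc1Cl` gives 7.04 in a physicochemical assay for lipophilicity, at pH 7.4 (on this read-out lower numbers stand for lower lipophilicity and higher numbers for higher lipophilicity), and stands highest of the three. Compound 1 `CC(C)Oc1ccc(-c2nnc(-n3cncn3)s2)cc1Cl` gives 6.18 in this assay, and compound 2 `Cc1[nH]ncc1-c1nnc(-c2ccc(OC(C)C)c(Cl)c2)s1` gives 5.45. Both steps ending at compound 3 lie beyond the scatter: a number 0.86 log units higher from compound 1 to compound 3 (beyond the scatter) and a number 1.59 log units higher from compound 2 to compound 3 (beyond the scatter). Compound 4 `CC(C)Oc1ccc(-c2nnc(-c3cncn3C)s2)cc1Cl` is not yet measured; it differs from compound 3 by 1-methyl-1H-imidazol-5-yl in place of 1-methyl-1H-pyrazol-5-yl on an aromatic carbon. Each measured step swapped one five-membered aromatic ring with 2 hetero atoms for another and moved the number by a modest to large amount, so a downward step of comparable size is expected here, namely a number 0.74 log units lower from compound 3 to compound 4 (beyond the scatter). For compound 4 the estimate in this assay is 6.3, with a range from 5.7 to 6.9.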

Compound 4, distribution coefficient: 5.7
Beside the measured number, compound 4's estimate is 0.60 log units above it; the range from low to high includes it.
By their numbers in this assay, from the lowest: compounds 2 and 4 (each within the scatter of the next); then compound 1; then compound 3.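

In this assay, two rings with the same atoms and the same counts of donors and acceptors lie far apart, a number 1.34 log units lower from compound 3 to compound 4 (beyond the scatter), so the arrangement of atoms within the ring alone can carry a large step at this position. The 1-methyl-1H-imidazol-5-yl group reads a number 0.48 log units lower from compound 1 to compound 4 (beyond the scatter) and a number 0.25 log units higher from compound 2 to compound 4 (within the scatter), so rings with the same number of hetero atoms span the whole measured range. No evidence on hand accounts for these steps. On these data alone, how a pyridine ring, or a ring carrying an amine or a carboxylic acid, would stand at this position remains open.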